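Series notes: N-methyl removal on the amino-pyrazole core

The source may hold more compounds than are shown below. What is called first, only, known or untested is meant among the compounds shown, and "the series" means these compounds.

Compound 2 `Cc1cc2c(c(N)nn2C)c(N2CCCCC2)n1` is the reference point of this small set; in an assay on isolated protein for inhibition of MAP kinase-activated protein kinase 5 (Homo sapiens), read by mobility shift assay, tested at 30 uM (a higher number here means more inhibition at the concentration tested (going by the name of the read-out), a lower number less inhibition), compound 2 gives 17%. Compound 1 `Cc1cc2[nH]nc(N)c2c(N2CCCCC2)n1` gives 10% in this assay, and compound 3 `Cc1cc2c(cn1)c(N)nn2C` gives 9%. Compound 4 `Cc1cc2[nH]nc(N)c2cn1` has not yet been measured.

The pair compound 2 and compound 1 differs by hydrogen in place of methyl on an aromatic nitrogen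
and this change made the step of a number 7 percentage points lower from compound 2 to compound 1 (within the scatter). The two cores differ by hydrogen in place of piperidin-1-yl on an aromatic carbon
with the step of a number 8 percentage points lower from compound 2 to compound 3 (within the scatter). The change from compound 3 to compound 4 is hydrogen in place of methyl on an aromatic nitrogen
and its place reads the same, word for word, as for the pair compound 2 to compound 1, so it is the same change on a core without the piperidin-1-yl group. The change occurs twice among the compounds shown.

For the measured compounds named here, for compound 4 the step of a number 4 percentage points lower from compound 3 to compound 4 (within the scatter) is expected, resting on the single measured instance a number 7 percentage points lower from compound 2 to compound 1 (within the scatter) of the same change. Compound 4 is therefore estimated at 5% in this assay, with a range from -5% to 17%.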

Compound 4, a percentage reported as inhibition, at one concentration (the size of the read-out at that concentration, not a potency): 13%
The estimate for compound 4 lay 8 percentage points below the measured number; the measured number falls inside the stated range.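

In this assay, hydrogen in place of methyl on the aromatic nitrogen of the core without piperidin-1-yl gives a number 4 percentage points higher from compound 3 to compound 4 (within the scatter), and setting this beside the earlier instance shows no difference between the two cores beyond the scatter: the same change on two cores in this assay, a number 7 percentage points lower (within the scatter) from compound 2 to compound 1 and a number 4 percentage points higher (within the scatter) from compound 3 to compound 4, 11 percentage points apart, within the scatter of two such steps

The opposite signs of the two steps are therefore no evidence that the core reverses the outcome of this change. Equally, the agreement does not show that a real effect carries from one core to the other, since each step lies within the scatter and neither shows that the change has any effect in this assay.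

The compounds shown leave open whether a larger group on the aromatic nitrogen, such as a longer chain in place of methyl, would give a step beyond the scatter. They also leave open how the same change behaves on a core bearing an open-chain amine or a carboxylic acid in place of piperidin-1-yl.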